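This account rests on a few compounds, and the source may have more. Where it says the series, first, only, none or still open, it means among the compounds named here.

Measured in a functional assay on K562 cells (Homo sapiens) for antiproliferative activity, read by MTT assay, with a stated time of 72 h; a higher number here means a weaker inhibitor, a lower number a stronger inhibitor:
Compound 1 `COc1cc(C(=O)c2sc3ccccc3c2-c2ccc(SC)cc2)cc(OC)c1OC`: 1800 nM
Compound 2 `CCOc1ccc(-c2c(C(=O)c3cc(OC)c(OC)c(OC)c3)sc3ccccc23)cc1`: 3100 nM

Among the measured compounds shown here, only two compounds have been measured in this assay, and compound 2, at 3100 nM, cannot be told apart from compound 1, at 1800 nM. For the measured compounds named here, the one measured step, a 1.7-fold higher number from compound 1 to compound 2 (0.24 log units; within the scatter), lies within the scatter. The next compound is compound 3 `COc1cc(C(=O)c2sc3ccccc3c2Nc2ccc(Cl)cc2)cc(OC)c1OC`, which carries (4-chlorophenyl)amino in place of 4-ethoxyphenyl on an aromatic carbon. That measured step bears on this change only indirectly, since it exchanged a group on the aromatic ring and left the attachment to the core unchanged. Going by the values given here, no measured step shows what the new amino attachment does. No shift beyond the scatter is therefore expected in this assay, in either direction, though with wide uncertainty. The estimate amounts to an expected 1.0-fold lower number from compound 2 to compound 3 (0.01 log units; within the scatter). Compound 3 is expected at 3000 nM, within an estimated range of 600 nM to 15000 nM.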

Compound 3, half-maximal inhibitory concentration: 1100 nM
Beside the measured number, compound 3's estimate is 2.7-fold (0.44 log units) above it, within the range that was stated.
By their numbers in this assay, from the lowest: compounds 3, 1 and 2 (each within the scatter of the next, the first and the last beyond it).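

In this assay, the aromatic carbon of the five-membered ring with 1 sulfur accepts (4-chlorophenyl)amino in place of a directly attached substituted phenyl group without any loss of activity. Replacing 4-ethoxyphenyl gave a 2.8-fold lower number from compound 2 to compound 3 (0.45 log units; beyond the scatter) and thus the first shift beyond the scatter in this series, but replacing 4-(methylsulfanyl)phenyl gave a 1.6-fold lower number from compound 1 to compound 3 (0.21 log units; within the scatter) and thus no clear change, so the gain holds against only one of the two reference groups. Nothing available explains this shift.

The nitrogen link and the chlorine entered in the same step, and their contributions remain unseparated. On these data alone, how a plain phenylamino group, or a methylene link in place of the amino nitrogen, would read at this position remains open.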